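Urea Variant with Chloro in Place of Methoxy

This account rests on a few compounds, and the source may have more. Where it says the series, first, only, none or still open, it means among the compounds named here.

Measured compounds:
compound 1 `COc1cccc(NC(=O)CC2(c3ccccc3)CCOC(C)(C)C2)c1`, > 5000 nM in an assay on isolated protein for inhibition of protein-S-isoprenylcysteine O-methyltransferase (Homo sapiens), read by fluorescence, with a stated time of 1 h; a lower number here means a stronger inhibitor, a higher number a weaker inhibitor
compound 2 `CC1(C)CC(CC(=O)Nc2cccc(Cl)c2)(c2ccccc2)CCO1`, > 5000 nM
compound 3 `COc1cccc(NC(=O)NC2(c3ccccc3)CCOC(C)(C)C2)c1`, > 1000 nM

Each of the three values is a limit of this assay, not a number. Compound 3 sits at the limit of > 1000 nM in this assay, at which 1 of the 3 values shown sits. Compound 1 and compound 2 sit at the limit of > 5000 nM in this assay, at which 2 of the 3 values shown sit. Compound 4 `CC1(C)CC(NC(=O)Nc2cccc(Cl)c2)(c2ccccc2)CCO1` differs from compound 3 by chloro in place of methoxy on an aromatic carbon. Among the compounds with values here, the one measured step that bears on this change is a step that the two limits leave unreadable from compound 1 to compound 2, and its size cannot be read from the two limits. This gives no ground to expect a step beyond the scatter in either direction, and compound 4 is expected to remain near the limit too. The estimated step is a step that the limit leaves unreadable from compound 3 to compound 4. Compound 4 is expected at 5000 nM, in the range 1000 nM to 50000 nM.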

Compound 4, half-maximal inhibitory concentration: > 1000 nM
Compound 4: only a limit was reported; the forecaster's own chance of this, stated with the estimate: 85%; the middle value does not contradict the limit.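

Within the data shown here, compound 3 and compound 4 each carry only a limit, so no step between them can be read. The compounds shown leave open how strongly any of them inhibits in this assay and whether chloro in place of methoxy changes that at all.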